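Amide nitrogen methyl removal in oxazole ketone series

The compounds below may be only part of what the source reports. "The series", "measured", "known", "first", "only" and "open" are said of these compounds alone.

Measured compounds:
compound 1 `CN(C)C(=O)c1cnc(C(=O)CCc2ccc(-c3ccccc3)cc2)o1` – 3 nM
compound 2 `CN(C)C(=O)c1cnc(C(=O)CCc2ccc(COc3ccccc3)cc2)o1` – 6.7 nM

Compound 2 `CN(C)C(=O)c1cnc(C(=O)CCc2ccc(COc3ccccc3)cc2)o1` stands at the higher of the two numbers in an assay for inhibition of Fatty-acid amide hydrolase 1 (Rattus norvegicus); on this read-out higher numbers stand for weaker inhibition and lower numbers for stronger inhibition. Going by the values given here, its nearest neighbour is compound 1 `CN(C)C(=O)c1cnc(C(=O)CCc2ccc(-c3ccccc3)cc2)o1`, which gives 3 nM, and the only measured step, a 2.2-fold higher number from compound 1 to compound 2 (0.35 log units; beyond the scatter), links them.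

Compound 3 `CNC(=O)c1cnc(C(=O)CCc2ccc(COc3ccccc3)cc2)o1` is not yet measured. It differs from compound 2 in one place: hydrogen in place of methyl on an amide-type nitrogen, so the dimethylcarbamoyl end of the shared core becomes methylcarbamoyl. Among the compounds with values here, no measured step in this set touches the amide nitrogen; the single step, a 2.2-fold higher number from compound 1 to compound 2 (0.35 log units; beyond the scatter), concerns the aromatic carbon at the other end of the molecule and does not bear on this change. There is therefore no basis in the series for expecting a shift in either direction, and the working expectation is a step around the scatter, a 1.0-fold higher number from compound 2 to compound 3 (0.02 log units; within the scatter), with the range kept wide for want of a precedent. Compound 3 is estimated at 7 nM in this assay, expected to fall between 2.5 nM and 20 nM.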

Compound 3, inhibition constant: 3.6 nM
Beside the measured number, compound 3's estimate is 1.9-fold (0.29 log units) above it, and the stated range covers the measured number.
By their numbers in this assay, from the lowest: compounds 1, 3 and 2 (each within the scatter of the next, the first and the last beyond it).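

In this assay, hydrogen in place of methyl on an amide-type nitrogen gives a 1.9-fold lower number from compound 2 to compound 3 (0.27 log units; within the scatter) and so leaves compound 2 and compound 3 within the scatter of each other. Going by these compounds alone, this is the first reading at this position: the only earlier step, a 2.2-fold higher number from compound 1 to compound 2 (0.35 log units; beyond the scatter), concerns an aromatic carbon at the other end of the molecule, whereas the new step shows that dimethylcarbamoyl can give way to methylcarbamoyl with no loss beyond the scatter on this read-out, at least with the phenoxymethyl group in place. No measurement at hand bears on the reason for this result.

The compounds shown leave open whether the remaining methyl can also be replaced, whether by hydrogen to give the unsubstituted carbamoyl group or by a longer chain such as ethyl, and whether a ring amide such as pyrrolidine-1-carbonyl or a carboxylic acid would be accepted at this end of the shared core. They also leave open whether methylcarbamoyl gives a similar reading when paired with the phenyl group of compound 1 rather than the phenoxymethyl group.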